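The source may report more compounds than this note shows. Statements on the series, on what has been measured and on what is new or still open speak of the compounds shown alone.

Among the compounds with values here, in a functional assay on Bel-7402 cells (Homo sapiens) for inhibition, read by MTT assay, with a stated time of 24 h, tested at 100 ug/mL (on this read-out higher numbers stand for more inhibition of growth at the one concentration tested and lower numbers for less inhibition of growth), compound 1 `CC(=O)SCCC(CCCCC(=O)Nc1ccccc1)SC(C)=O` gives 14.1% and compound 2 `CC(=O)SCCC(CCCCC(=O)Nc1cccc(Cl)c1)SC(C)=O` gives 20.8% and these two values lie within the usual scatter of each other, so compound 2 cannot be ranked apart from compound 1, its only measured neighbour. Compound 3 `CC(=O)SCCC(CCCCC(=O)Nc1ccc(Cl)cc1)SC(C)=O` holds the same atoms joined differently, and the change is 4-chlorophenyl in place of 3-chlorophenyl on an amide-type nitrogen. Within the data shown here, one measured step bears on this, chloro in place of hydrogen on an aromatic carbon, which gave a number 6.7 percentage points higher from compound 1 to compound 2 (within the scatter) and so stayed small. Among the measured compounds shown here, no measured pair compares the two chlorophenyl groups directly, so the expectation rests on that single step. In this assay no step beyond the scatter is therefore expected. The estimated step is a number 0.2 percentage points higher from compound 2 to compound 3 (within the scatter) and it stays inside the scatter. For compound 3 the estimate is 21% with an expected range from 11% to 34% on this read-out.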

Compound 3, percent growth inhibition at one concentration: 45.5%
Compound 3: middle estimate off by 24.5 percentage points, on the low side, outside the stated range (above it).
By their numbers in this assay, from the lowest: compounds 1 and 2 (each within the scatter of the next); then compound 3.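

In this assay, where the chlorine sits matters and not only whether it is present: 4-chlorophenyl in place of 3-chlorophenyl on the amide-type nitrogen gives a number 24.7 percentage points higher from compound 2 to compound 3 (beyond the scatter), although the two compounds hold the same atoms. Chloro in place of hydrogen on an aromatic carbon can therefore give a number 31.4 percentage points higher from compound 1 to compound 3 (beyond the scatter), whereas the earlier chloro step gave only a number 6.7 percentage points higher from compound 1 to compound 2 (within the scatter). Nothing at hand explains why the two placements differ.

The compounds shown leave open whether this gain belongs to chlorine itself, which a bromine, a methyl or a methoxy group in place of the chlorine of 4-chlorophenyl could test. They also leave open whether the gain holds when the two thioacetate arms of the shared core are replaced, for example by free thiols.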